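This account rests on a few compounds, and the source may have more. Where it says the series, first, only, none or still open, it means among the compounds named here.

Measured so far in a functional assay on the whole organism (strain Wistar) for inhibition, with Rattus norvegicus as the target, read by paw edema, with stated times of 1 h and 5 h, at a dose of 20 mg/kg by the oral route; on this read-out lower numbers stand for less inhibition and higher numbers for more inhibition at the one dose given (going by the name of the read-out):
compound 1, `COc1ccc(C2CC(c3ccc(Br)cc3)=NN2c2nc3ccc(S(N)(=O)=O)cc3s2)cc1`: 14%
compound 2, `COc1ccc(C2CC(c3ccc(Cl)cc3)=NN2c2nc3ccc(S(N)(=O)=O)cc3s2)cc1`: 67.7%
compound 3, `NS(=O)(=O)c1ccc2nc(N3N=C(c4ccc(Br)cc4)CC3c3cccs3)sc2c1`: 14%

The three share one core and differ at two places. Compound 1 and compound 2 differ by chloro in place of bromo on an aromatic carbon; the step is a number 53.7 percentage points higher from compound 1 to compound 2 (beyond the scatter). Compound 1 and compound 3 differ at the other place, (thiophen-2-yl in place of 4-methoxyphenyl on a saturated ring carbon), and the step is no change at the digits printed from compound 1 to compound 3 (within the scatter), so compound 1 and compound 3 sit together at the low end of the series, with compound 2 the only one that stands apart.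

Compound 4, `NS(=O)(=O)c1ccc2nc(N3N=C(c4ccc(Cl)cc4)CC3c3cccs3)sc2c1`, has not been measured. Within the data shown here, it differs from compound 3 by chloro in place of bromo on an aromatic carbon, which is the same change, at the same place, as the one from compound 1 to compound 2. Whether the step carries over onto the core of compound 3 rests on that one pair alone; nothing else in the series speaks to it. From compound 3 to compound 4 a step of about a number 31 percentage points higher from compound 3 to compound 4 (beyond the scatter) is expected, because the earlier step of a number 53.7 percentage points higher from compound 1 to compound 2 (beyond the scatter) was large and the starting values of compound 1 and compound 3 coincide. Compound 4 is therefore estimated at 45%, with a likely range from 15% to 70%.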

Compound 4, a percentage reported as inhibition, in the whole organism at one dose (the size of the read-out at that dose, not a potency): 14%
Compound 4: middle estimate off by 31 percentage points, on the high side; measured number outside the range, below it.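

In this assay, chloro in place of bromo on an aromatic carbon gives no change at the digits printed from compound 3 to compound 4 (within the scatter), so the change does not carry over from the core of compound 1 to the core of compound 3: the same change on two cores in this assay, a number 53.7 percentage points higher (beyond the scatter) from compound 1 to compound 2 and no change at the digits printed (within the scatter) from compound 3 to compound 4, 53.7 percentage points apart, beyond the scatter of two such steps

Read at the other place, thiophen-2-yl in place of 4-methoxyphenyl on a saturated ring carbon gives a number 53.7 percentage points lower from compound 2 to compound 4 (beyond the scatter), so that change also depends on its core: the same change on two cores in this assay, no change at the digits printed (within the scatter) from compound 1 to compound 3 and a number 53.7 percentage points lower (beyond the scatter) from compound 2 to compound 4, 53.7 percentage points apart, beyond the scatter of two such steps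

The two places therefore do not add up independently here, and among the four compounds only compound 2, with chloro and 4-methoxyphenyl together, stands apart, but a single pair of cores per change gives neither a reason for this nor a rule for other cores.

From the compounds shown here alone, it remains open whether the high number of compound 2 depends on the methoxy group itself, or would persist with a hydroxy group, an amine or a plain phenyl in its place. Fluoro in place of chloro on the same aromatic carbon, and a carboxylic acid in place of the sulfonamide, are also untested in the compounds shown.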